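This account rests on a few compounds, and the source may have more. Where it says the series, first, only, none or still open, it means among the compounds named here.

Measured so far:
- compound 1 `COc1ccc(CNC(=O)c2nc(-c3ccc(F)cc3)n(CC[C@@H](O)C[C@@H](O)CC(=O)O)c2C2CC2)cc1F`: 3.7 nM
- compound 2 `O=C(O)C[C@H](O)C[C@H](O)CCn1c(-c2ccc(F)cc2)nc(C(=O)NCc2ccc(F)c(F)c2)c1C1CC1`: 1.2 nM
- compound 3 `O=C(O)C[C@H](O)C[C@H](O)CCn1c(-c2ccc(F)cc2)nc(C(=O)NCc2cccc(F)c2)c1C1CC1`: 1.2 nM

In an assay on microsomes from liver for inhibition of 3-hydroxy-3-methylglutaryl-coenzyme A reductase (Rattus norvegicus), read by scintillation counting, with stated times of 0.5 h and 0.75 h (a lower number here means a stronger inhibitor, a higher number a weaker inhibitor), compound 3 stands level with compound 2, and together they give the lowest numbers of the three; the step of no change at the digits printed from compound 2 to compound 3 (within the scatter) lies within the scatter, so the two cannot be ranked. Compound 1, which carries a methoxy on an aromatic carbon where compound 3 carries hydrogen, gives the highest number, and the step of a 3.1-fold lower number from compound 1 to compound 3 (0.49 log units; beyond the scatter) is modest but beyond the scatter.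

Compound 4 `COc1ccc(CNC(=O)c2nc(-c3ccc(F)cc3)n(CC[C@@H](O)C[C@@H](O)CC(=O)O)c2C2CC2)cc1` differs from compound 3 in one place: 4-methoxyphenyl in place of 3-fluorophenyl on a saturated chain carbon bound to an amide-type nitrogen. Among the measured compounds shown here, two measured steps bear on this. The step of a 3.1-fold lower number from compound 1 to compound 3 (0.49 log units; beyond the scatter) shows that taking the methoxy away lowers the number; putting it back should raise it by about the same amount. The step of no change at the digits printed from compound 2 to compound 3 (within the scatter) shows that fluorine against hydrogen makes no difference beyond the scatter. The expected step is therefore a 2.9-fold higher number from compound 3 to compound 4 (0.46 log units; beyond the scatter), a modest rise in this assay, bringing compound 4 close to compound 1. Compound 4 is estimated at 3.5 nM, within a range of 1.5 nM to 8 nM.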

Compound 4, half-maximal inhibitory concentration: 1.2 nM
Compound 4: middle estimate off by 2.9-fold (0.46 log units), on the high side; the measured number lies below the stated range.
By their numbers in this assay, from the lowest: compounds 2, 3 and 4 (each within the scatter of the next); then compound 1.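

Replacing 3-fluorophenyl with 4-methoxyphenyl at this position gives no change at the digits printed from compound 3 to compound 4 (within the scatter), and replacing 3,4-difluorophenyl with it gives no change at the digits printed from compound 2 to compound 4 (within the scatter), so in this assay a methoxy on this ring is tolerated when no fluoro accompanies it. The higher number of compound 1 therefore goes with the methoxy and fluoro together: taking the fluoro off gives a 3.1-fold lower number from compound 1 to compound 4 (0.49 log units; beyond the scatter). Swapping fluoro for hydrogen thus has no single fixed effect, since its size depends on the rest of the ring, as the same change on two cores shows: the same change on two cores in this assay, no change at the digits printed (within the scatter) from compound 2 to compound 3 and a 3.1-fold lower number (0.49 log units; beyond the scatter) from compound 1 to compound 4, 3.1-fold (0.49 log units) apart, beyond the scatter of two such steps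

The compounds shown do not tell why the fluoro matters in compound 1 yet makes no visible difference between compound 2 and compound 3. They also leave open whether a chloro or a methyl in place of that fluoro would raise the number too, and whether an ethoxy in place of the methoxy of compound 4 would be tolerated.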